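The compounds below may be only part of what the source reports. "The series", "measured", "known", "first", "only" and "open" are said of these compounds alone.

Measured compounds in an ADME assay on L02 cells (Homo sapiens) for cytotoxicity, read by MTT assay, with a stated time of 24 h; on this read-out higher numbers stand for weaker inhibition and lower numbers for stronger inhibition:
compound 1, `CN1C/C(=C\c2ccc(C#N)cc2)C(=O)/C(=C/c2cccnc2)C1`: > 20000 nM
compound 2, `CN1C/C(=C\c2ccncc2)C(=O)/C(=C/c2ccc(C#N)cc2)C1`: 14000 nM
compound 3, `O=C1/C(=C/c2cccnc2)CNC/C1=C\c1ccccc1C(F)(F)F`: 11300 nM

Compound 1 reaches only a limit of this assay, namely > 20000 nM; this is the limit of > 20000 nM in this assay, at which 1 of the 3 values shown sits. Compound 2 and compound 3 give numbers, and their two numbers lie within the usual scatter of each other, so no order between them is claimed. Among the measured compounds shown here, the one counted change among the measured compounds is pyridin-4-yl in place of pyridin-3-yl on a double-bonded chain carbon bound to a double-bonded ring carbon, and its step is an at least 1.4-fold lower number from compound 1 to compound 2 (0.15 log units; that floor lies within the scatter). On these data alone, since the starting value is a limit, the true size of that step is unknown beyond its floor.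

Compound 4, `O=C1/C(=C/c2ccncc2)CNC/C1=C\c1ccccc1C(F)(F)F`, has not yet been measured. It differs from compound 3 by pyridin-4-yl in place of pyridin-3-yl on a double-bonded chain carbon bound to a double-bonded ring carbon, which is the same change as from compound 1 to compound 2, made at the same place. How the core of compound 3 differs from the core of compound 1 is not broken down here.

For the measured compounds named here, for compound 4 in this assay the step is expected to be a 1.3-fold lower number from compound 3 to compound 4 (0.10 log units; within the scatter), resting on the single earlier step of an at least 1.4-fold lower number from compound 1 to compound 2 (0.15 log units; that floor lies within the scatter) whose floor is within the scatter. Compound 4 is therefore estimated at 9000 nM, with a range from 4500 nM to 20000 nM.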

Compound 4, half-maximal inhibitory concentration: 13400 nM
Compound 4: the middle estimate sits 1.5-fold (0.17 log units) below what was measured; the measured number falls inside the stated range.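

On the second core, in this assay, pyridin-4-yl in place of pyridin-3-yl on a double-bonded chain carbon bound to a double-bonded ring carbon gives a 1.2-fold higher number from compound 3 to compound 4 (0.07 log units; within the scatter), so this pair shows no change in the read-out beyond the scatter. Set beside the earlier step, the comparison of the two cores stands as follows: the same change on two cores in this assay, an at least 1.4-fold lower number (0.15 log units; that floor lies within the scatter) from compound 1 to compound 2 and a 1.2-fold higher number (0.07 log units; within the scatter) from compound 3 to compound 4; the limit leaves it open whether they differ. Compound 1 sits at a limit and not at a number, so the notes can show neither that the change carries over from one core to the other with the same size nor that it does not: the limit of > 20000 nM in this assay, at which 1 of the 4 values shown sits.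

The compounds shown leave open whether a group other than the two pyridines at this place, such as a carboxylic acid, an amine or a longer chain ending in an amine, would move the read-out beyond the scatter. They also leave open how the nitrile-bearing and trifluoromethyl-bearing parts of the two cores act on their own, since no pair shown differs in one of these alone.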